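Replacing the 4-propylphenyl group of compound 1

The compounds below may be only part of what the source reports. "The series", "measured", "known", "first", "only" and "open" are said of these compounds alone.

compound 1 `CCCc1ccc(C#CC#Cc2cn([C@H]3C[C@H](O)[C@@H](CO)O3)c(=O)[nH]c2=O)cc1` gives 2.36
compound 2 `Nc1cccc(C#CC#Cc2cn([C@H]3C[C@H](O)[C@@H](CO)O3)c(=O)[nH]c2=O)c1` gives 0.13
compound 3 `Nc1ccc(C#CC#Cc2cn([C@H]3C[C@H](O)[C@@H](CO)O3)c(=O)[nH]c2=O)cc1` gives 0.13

All three were measured in a physicochemical assay for lipophilicity (a lower number here means a more polar compound, a higher number a more lipophilic compound), and compound 1 has the highest number of them. Compound 4 `O=c1[nH]c(=O)n([C@H]2C[C@H](O)[C@@H](CO)O2)cc1C#CC#CCC1CCCC1` has not been measured yet. It differs from compound 1 in one place, on a triple-bonded carbon: cyclopentylmethyl in place of 4-propylphenyl on a triple-bonded carbon. Put simply, cyclopentylmethyl stands in place of 4-propylphenyl.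

The measured steps show a number 2.23 log units lower from compound 1 to compound 2 (beyond the scatter) and a number 2.23 log units lower from compound 1 to compound 3 (beyond the scatter), both large. They also show no change at the digits printed from compound 2 to compound 3 (within the scatter) when 4-aminophenyl stands in place of 3-aminophenyl. None of these compounds carries cyclopentylmethyl, and the entering group has no amino group, so these steps give only loose guidance. A fall smaller than the step to compound 3 of a number 2.23 log units lower from compound 1 to compound 3 (beyond the scatter) therefore seems the fair expectation. The expected change is a number 0.76 log units lower from compound 1 to compound 4 (beyond the scatter). For compound 4 the estimated value is 1.6, with an expected range from 1 to 2.2.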

Compound 4, partition coefficient: 1.43
Beside the measured number, compound 4's estimate is 0.17 log units above it; measured number inside the range.
By their numbers in this assay, from the lowest: compounds 2 and 3 (each within the scatter of the next); then compound 4; then compound 1.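

In this assay this position on a triple-bonded carbon also tolerates a group without an aromatic ring, and swapping 4-propylphenyl for cyclopentylmethyl gives a number 0.93 log units lower from compound 1 to compound 4 (beyond the scatter) while the comparisons with the amino compounds give a number 1.30 log units higher from compound 3 to compound 4 (beyond the scatter) and a number 1.30 log units higher from compound 2 to compound 4 (beyond the scatter) in this series. The leaving and entering groups both count no hydrogen-bond donors or acceptors, so the number moved beyond the scatter with those counts unchanged, while the heavy-atom count and ring type differ. No measurement shown explains this shift. The compounds shown leave open whether ring size, the linking carbon or the total carbon count matters most. Cyclohexylmethyl, plain cyclopentyl or an open pentyl chain at this position would help separate these features, and an amine on the cyclopentyl ring would test the amino step without an aromatic ring.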